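The source may hold more compounds than are shown below. What is called first, only, known or untested is meant among the compounds shown, and "the series" means these compounds.

Of the compounds shown here, two sharing one core have been tested in a functional assay on the whole organism with Mus musculus as the target, in the maximal electroshock model; a lower number here means that less compound is needed, a higher number that more compound is needed for the effect. Compound 1 `Nc1nnc(-c2ccccc2OCc2ccc(Cl)cc2)o1` and compound 2 `Sc1nnc(-c2ccccc2OCc2ccccc2)o1` differ in a single group on that core. In this assay compound 1 gives only a limit of the assay, > 100 mg/kg. In this assay compound 2 also gives only a limit, >= 100 mg/kg. Compound 2 thus stands at the limit of >= 100 mg/kg in this assay, at which 1 of the 2 values shown sits, and no number has been reached for it. Compound 3 `CCSc1nnc(-c2ccccc2OCc2ccccc2)o1` has not been measured; it differs from compound 2 by ethyl in place of hydrogen on a sulfur. Among the measured compounds shown here, no step between two measured compounds is available to judge this kind of change. The value of compound 3 is expected to remain close to the limit found for compound 2, a step of a number no higher from compound 2 to compound 3 (the limit leaves the size open) that is not expected to exceed the scatter. The estimate for compound 3 in this assay is 100 mg/kg, with a range from 30 mg/kg to 300 mg/kg.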

Compound 3, dose for half-maximal effect: > 100 mg/kg
Compound 3: a limit, no number; the forecaster's own chance of this, stated with the estimate: 60%; the middle value lies on the limit itself.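

In this assay compound 2 and compound 3 both give only a limit of the assay, so no step can be read between them. The compounds shown leave open what dose each would need for the effect, and so whether ethyl in place of hydrogen on a sulfur changes that dose at all.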